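A few compounds are considered here, and "the series" means these few. Any claim that something is new, unique, unknown or untested is made for them only; others in the source may bear on it.

Measured compounds:
compound 1, `COCCNc1nc(NCC2CC2)cc(-c2ccccn2)n1`, giving 10000 nM
compound 2, `CNc1nc(NCc2ccc(NS(C)(=O)=O)cc2)cc(-c2ccccn2)n1`, giving 8 nM

In a functional assay on HEK293 cells for agonist activity at G-protein coupled receptor 39 (Mus musculus), read by inositol phosphate accumulation (on this read-out higher numbers stand for an effect only at larger amounts of compound and lower numbers for an effect already at smaller amounts), compound 1 gives 10000 nM, the highest of the two numbers recorded. The nearest neighbour, compound 2, gives 8 nM, a much lower number, and that gap lies beyond the scatter. Compound 2 differs from compound 1 in more than one place, so the two values only show how far apart these two compounds sit; no single change is isolated by them.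

Compound 3, `CN(C)c1nc(NCC2CC2)cc(-c2ccccn2)n1`, is not yet measured. It differs from compound 1 in one place: dimethylamino in place of (2-methoxyethyl)amino on an aromatic carbon. The group that leaves carries one hydrogen-bond donor, the group that enters carries none, and the chain that enters is shorter. Within the data shown here, no measured pair in this set shows what such a change does, so the expectation rests on the weak starting point alone. Compound 1 already stands at the weak end, and the step from compound 1 to compound 3 is expected to be a 1.2-fold higher number from compound 1 to compound 3 (0.08 log units; within the scatter), with no clear direction beyond the scatter. For compound 3 the estimate in this assay is 12000 nM, with a range from 2500 nM to 60000 nM.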

Compound 3, half-maximal effective concentration: 6720 nM
Compound 3: middle estimate off by 1.8-fold (0.25 log units), on the high side, within the range that was stated.
By their numbers in this assay, from the lowest: compound 2; then compounds 3 and 1 (each within the scatter of the next).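

In this assay, among these compounds, dimethylamino in place of (2-methoxyethyl)amino on the aromatic carbon between two ring nitrogen atoms gives a 1.5-fold lower number from compound 1 to compound 3 (0.17 log units; within the scatter) and so provides the first comparison in this set that isolates a single change. With the (cyclopropylmethyl)amino and pyridin-2-yl groups held constant, a group with no hydrogen-bond donor and fewer heavy atoms at this position gives a number within the scatter of the one given by (2-methoxyethyl)amino. Nothing measured here explains why these two groups read alike.

Going by these compounds, whether a primary amine or a longer chain ending in a carboxylic acid at this position would give a step beyond the scatter remains open. On these data alone, it is also open whether dimethylamino and (2-methoxyethyl)amino would still read alike with another group in place of (cyclopropylmethyl)amino, and compound 2 cannot settle this, as it differs from compound 1 and compound 3 in more than one place.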